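The source may report more compounds than this note shows. Statements on the series, on what has been measured and on what is new or still open speak of the compounds shown alone.

Compound 1 `ClCCOC[C@H]1CO1` is one of three compounds tested in an ADME assay on BHK cells (Mesocricetus auratus) for cytotoxicity, read by XTT assay; on this read-out higher numbers stand for lower toxicity in this test and lower numbers for higher toxicity in this test. In this assay compound 1 gives > 1000000 nM, which is a limit of the test rather than a number. Compound 2 `ON=C(C[C@@H]1COCCO1)C[C@@H]1COCCO1` gives > 1000000 nM, again only a limit. Compound 3 `C(CC[C@@H]1COCCO1)C[C@@H]1COCCO1` gives > 1000000 nM, also a limit. So compound 3 stands at the limit that all three measured values share (the limit of > 1000000 nM in this assay, at which 3 of the 3 values shown sit), and no step between measured compounds can be sized. Compound 4 `OC(CC[C@@H]1COCCO1)C[C@@H]1COCCO1` differs from compound 3 by hydroxy in place of hydrogen on a saturated chain carbon bound to two saturated chain carbons. With nothing measured beyond that shared limit, the expected step of a number no higher from compound 3 to compound 4 (the limit leaves the size open) is none beyond the usual scatter. Compound 4 is therefore expected to reach 1000000 nM, within 300000 nM to 3000000 nM, most likely again reported only as a limit.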

Compound 4, half-maximal cytotoxic concentration: > 1000000 nM
Compound 4 ended at the assay's limit (the forecaster's own chance of this, stated with the estimate: 85%); the middle value lies on the limit itself.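

For the compounds shown here, compound 3 and compound 4 both end at a limit of the test, so no step between them can be read: the limit of > 1000000 nM in this assay, at which 4 of the 4 values shown sit. The compounds shown leave open whether hydroxy in place of hydrogen changes the read-out in this assay at all.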